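Compound 2 to compound 3: bromo in place of methoxy

A few compounds are considered here, and "the series" means these few. Any claim that something is new, unique, unknown or untested is made for them only; others in the source may bear on it.

In a functional assay on MGC-803 cells (Homo sapiens) for inhibition, read by CCK-8 assay, with a stated time of 48 h (on this read-out lower numbers stand for stronger inhibition and higher numbers for weaker inhibition), compound 1 `COc1cc(N(Cc2ccc(Br)cc2)C(=O)CSC(=S)N2CCN(C(=O)OC(C)(C)C)CC2)cc(OC)c1OC` gives 12400 nM. Compound 2 `COc1ccc(CN(C(=O)CSC(=S)N2CCN(C(=O)OC(C)(C)C)CC2)c2cc(OC)c(OC)c(OC)c2)cc1OC` gives > 20000 nM, which is a limit and not a number. Compound 3 `COc1ccc(CN(C(=O)CSC(=S)N2CCN(C(=O)OC(C)(C)C)CC2)c2cc(OC)c(OC)c(OC)c2)cc1Br` has 3-bromo-4-methoxybenzyl in place of 3,4-dimethoxybenzyl, bromo in place of methoxy on an aromatic carbon. Among the compounds with values here, the one measured step bearing on this, an at least 1.6-fold higher number from compound 1 to compound 2 (0.20 log units; that floor lies within the scatter), has 3,4-dimethoxyphenyl in place of 4-bromophenyl. On that step alone, a small move toward a lower number is expected in this assay, and the estimated step is an at least 1.4-fold lower number from compound 2 to compound 3 (0.15 log units; that floor lies within the scatter). Compound 3 is estimated at 14000 nM, with an expected range of 6000 nM to 30000 nM.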

Compound 3, half-maximal inhibitory concentration: 3710 nM
The estimate for compound 3 lay 3.8-fold (0.58 log units) above the measured number; measured number outside the range, below it.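

In this assay, bromo in place of methoxy on 3,4-dimethoxybenzyl gives an at least 5.3-fold lower number from compound 2 to compound 3 (0.73 log units; beyond the scatter), so a change at this aromatic carbon now reads beyond the scatter, which the floor of the earlier step did not. With the methoxy group kept beside the new bromo, 3-bromo-4-methoxyphenyl in place of 4-bromophenyl gives a 3.3-fold lower number from compound 1 to compound 3 (0.52 log units; beyond the scatter). The figure for compound 2 is a limit and not a number: the limit of > 20000 nM in this assay, at which 1 of the 3 values shown sits.

Going by these compounds, whether chloro, methyl or an amine at this carbon would serve as bromo does stays open. So does the number for 3-bromobenzyl without the methoxy group.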